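Nitro in place of bromo: notes on compound 3

The source may hold more compounds than are shown below. What is called first, only, known or untested is meant among the compounds shown, and "the series" means these compounds.

Among the measured compounds shown here, in a functional assay on the whole organism with Mus musculus as the target (on this read-out lower numbers stand for an effect already at smaller amounts and higher numbers for an effect only at larger amounts of compound), compound 1 (`COc1cc2c(cc1OC)C(c1ccc(Br)cc1)=NN(C)C(=S)C2`) gives 60.4 umol/kg, the only actual number so far. Compound 2 (`COc1cc2c(cc1OC)C(c1cccc([N+](=O)[O-])c1)=NNC(=O)C2`) gives > 120 umol/kg, which is a limit and not a number. Compound 3 (`COc1cc2c(cc1OC)C(c1ccc([N+](=O)[O-])cc1)=NN(C)C(=S)C2`) has nitro in place of bromo on an aromatic carbon, para to a large group, and otherwise keeps the core of compound 1: nitro in place of bromo on an aromatic carbon. For the measured compounds named here, no measured step bears on this change, so no shift beyond the usual scatter is expected in this assay. The expected change is a 1.2-fold lower number from compound 1 to compound 3 (0.08 log units; within the scatter). For compound 3 the estimated value is 50 umol/kg, with an expected range of 22 umol/kg to 115 umol/kg.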

Compound 3, dose for half-maximal effect: 81.5 umol/kg
Compound 3: the middle estimate sits 1.6-fold (0.21 log units) below what was measured; the measured number falls inside the stated range.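

Among the compounds shown here, at this aromatic carbon, para to a large group, nitro in place of bromo gives a 1.3-fold higher number from compound 1 to compound 3 (0.13 log units; within the scatter) in this assay and is the only step that can be read. On this read-out, the two groups are not told apart at this position. Nothing measured here gives a reason for this step.

Open, as far as these compounds go, is whether an amine or a carboxylic acid at this position would give a step beyond the scatter. Also open, from the compounds shown here alone, is whether nitro in place of bromo elsewhere on the same ring would give a similar step.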